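This account rests on a few compounds, and the source may have more. Where it says the series, first, only, none or still open, it means among the compounds named here.

Working notes on the series in a functional assay for antagonist activity at 5-hydroxytryptamine receptor 4 (Rattus norvegicus); a higher number here means a more potent compound, by a factor of ten per unit of this negative logarithm, a lower number a less potent compound.

The shared core is that of compound 1 `CCOc1cc(N)c(Cl)cc1C(=O)CCCCN1CCCCC1`, with a methyl on the chain carbon bound to the aryl oxygen. In this assay compound 1 gives only a limit, < 7, which is the limit of < 7 in this assay, at which 1 of the 3 values shown sits. Compound 2 `COc1cc(COc2cc(N)c(Cl)cc2C(=O)CCCCN2CCCCC2)cc(OC)c1` carries a 3,5-dimethoxyphenyl in that place and in this assay gives 8.5; the step is a number at least 1.50 log units higher from compound 1 to compound 2 (beyond the scatter). Compound 3 `COc1ccc(CCOc2cc(N)c(Cl)cc2C(=O)CCCCN2CCCCC2)cc1OC` carries a 3,4-dimethoxybenzyl there and in this assay gives 6.8; the step is a number 1.70 log units lower from compound 2 to compound 3 (beyond the scatter), while the step from the limit of compound 1 is a step that the limit leaves unreadable from compound 1 to compound 3. Compound 2 therefore stands highest of the two numbers shown, with compound 3 nearest and beyond the scatter below it.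

Compound 4 `COc1cc(COc2cc(N)c(Cl)cc2C(=O)CCCCN2CCC(c3ccccc3)CC2)cc(OC)c1` keeps the ether side of compound 2 unchanged and differs only in phenyl in place of hydrogen on a saturated ring carbon. Among the measured compounds shown here, none of the measured steps touches the saturated ring: all three vary the group on the chain carbon bound to the aryl oxygen, so no measured step bears directly on this change. With the potent ether side of compound 2 retained, compound 4 is expected to stay near it, with the step from no change at the digits printed from compound 2 to compound 4 (within the scatter) estimated as none beyond the scatter. Compound 4 is thus estimated at 8.5, within 7.7 to 9.3.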

Compound 4, negative logarithm of the antagonist equilibrium constant: 7.7
Compound 4: the middle estimate sits 0.80 log units above what was measured; the measured number falls inside the stated range.
By their numbers in this assay, from the lowest: compound 3; then compound 4; then compound 2.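

The saturated ring now proves to be a position that registers in this assay: every earlier step varied the group on the chain carbon bound to the aryl oxygen, whereas here, with the 3,5-dimethoxyphenyl ether side held fixed, 4-phenylpiperidin-1-yl in place of piperidin-1-yl gives a number 0.80 log units lower from compound 2 to compound 4 (beyond the scatter) and the change lies beyond the scatter. The step is modest, so the phenyl, three ring bonds from the ring nitrogen, lowers the number without undoing the gain carried by that ether side, and compound 4 still reads 7.7 in this series. Nothing given here bears on why this change lowers the number.

Only hydrogen and phenyl are shown on this ring carbon, so it stays open whether the drop belongs to the phenyl itself or would also follow from a smaller group such as a methyl or a hydroxyl, or from a larger one such as a benzyl. The phenyl is also shown with the ether side of compound 2 alone, so whether the step carries over to the 3,4-dimethoxybenzyl of compound 3 remains unknown.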